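Aryl versus cyclohexyl amines on the shared core

The source may hold more compounds than are shown below. What is called first, only, known or untested is meant among the compounds shown, and "the series" means these compounds.

Compound 3 `O=C1C(NC2CCCCC2)=CC(=O)c2c1nc1n2[C@H]2OC[C@@H](O)[C@H]2OC1` reaches only the limit of a functional assay on MGC-803 cells (Homo sapiens) for inhibition, read by sulforhodamine B assay (on this read-out lower numbers stand for stronger inhibition and higher numbers for weaker inhibition), giving > 8000 nM. Compound 1 `O=C1C(Nc2cccc(Cl)c2)=CC(=O)c2c1nc1n2[C@H]2OC[C@@H](O)[C@H]2OC1` gives 1530 nM in this assay, and compound 2 `CCOc1ccccc1NC1=CC(=O)c2c(nc3n2[C@H]2OC[C@@H](O)[C@H]2OC3)C1=O` gives 2830 nM. The two steps that end at compound 3, an at least 5.2-fold higher number from compound 1 to compound 3 (0.71 log units; beyond the scatter) and an at least 2.8-fold higher number from compound 2 to compound 3 (0.45 log units; beyond the scatter), both run from an aryl group to cyclohexyl and both weaken inhibition, whereas a 1.8-fold higher number from compound 1 to compound 2 (0.27 log units; within the scatter) leaves the two aryl groups close together. Compound 4 `CCc1ccc(NC2=CC(=O)c3c(nc4n3[C@H]3OC[C@@H](O)[C@H]3OC4)C2=O)cc1` reverses that direction: 4-ethylphenyl in place of cyclohexyl on an amine nitrogen. Because compound 3 sits at the limit of > 8000 nM in this assay, at which 1 of the 3 values shown sits, the size of the gain can only be gauged as a lower bound. On the two aryl-to-cyclohexyl steps, inhibition is expected to strengthen by an at least 4.0-fold lower number from compound 3 to compound 4 (0.60 log units; beyond the scatter). Compound 4 is therefore estimated at 2000 nM, in the range 800 nM to 6000 nM.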

Compound 4, half-maximal inhibitory concentration: 1110 nM
Compound 4: the middle estimate sits 1.8-fold (0.26 log units) above what was measured; low and high end bracket the measured number.
By their numbers in this assay, from the lowest: compounds 4, 1 and 2 (each within the scatter of the next, the first and the last beyond it). At a limit, above all of these: compound 3.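

A third aryl group, 4-ethylphenyl, again stands clear of cyclohexyl on this amine nitrogen in this assay, so the aryl preference now rests on three groups. The first separation among aryl groups also appears: a 2.5-fold lower number from compound 2 to compound 4 (0.41 log units; beyond the scatter) lies beyond the scatter, whereas a 1.4-fold lower number from compound 1 to compound 4 (0.14 log units; within the scatter) stays within it. The step of an at least 7.2-fold lower number from compound 3 to compound 4 (0.85 log units; beyond the scatter) gives only a lower bound, because the value of compound 3 is a limit: the limit of > 8000 nM in this assay, at which 1 of the 4 values shown sits.

Open, from the compounds shown here alone, is whether the 2-ethoxyphenyl gap follows from the ethoxy group or from its ring placement. Also open, going by these compounds, is how an open-chain hexyl group, a benzyl group or a carboxylic acid on the phenyl ring would read.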